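The compounds below may be only part of what the source reports. "The series", "measured", "known", "first", "only" and "open" are said of these compounds alone.

Working notes on the series. In an assay on HEK293 cells for inhibition of transient receptor potential cation channel subfamily V member 6 (Homo sapiens), read by FLIPR, with a stated time of 5 min (on this read-out lower numbers stand for stronger inhibition and higher numbers for weaker inhibition), compound 1 `Fc1ccc([B-]2(c3ccc(F)cc3)[NH2+]CCO2)cc1` gives 14200 nM. Within the data shown here, compound 2 `Fc1ccc([B-]2(c3ccccc3)[NH2+]CCO2)cc1` gives 33600 nM in this assay, the highest of the two numbers measured so far; its nearest neighbour is compound 1, and the single measured step, a 2.4-fold higher number from compound 1 to compound 2 (0.37 log units; beyond the scatter), separates them.

The next compound, compound 3 `Cc1ccc([B-]2(c3ccccc3)[NH2+]CCO2)cc1`, differs from compound 2 by methyl in place of fluoro on an aromatic carbon. Among the measured compounds shown here, only one measured step exists to judge this by, and it bears on the change indirectly: it concerns the loss of a fluoro on the other ring of the shared core, and a 2.4-fold higher number from compound 1 to compound 2 (0.37 log units; beyond the scatter) was modest. For the measured compounds named here, an exchange of fluoro for methyl on the remaining substituted ring has no precedent among the measured compounds. A small drift toward a higher number is considered possible because a 2.4-fold higher number from compound 1 to compound 2 (0.37 log units; beyond the scatter) showed that removing fluoro raised the number, but a step clearly beyond the scatter is not expected in this assay.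

Compound 3 is therefore estimated at about 40000 nM, within a range from 15000 nM to 110000 nM, in this assay. The expected step of a 1.2-fold higher number from compound 2 to compound 3 (0.08 log units; within the scatter) is judged to lie inside the usual scatter.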

Compound 3, half-maximal inhibitory concentration: 12900 nM
For compound 3 the middle estimate is 3.1-fold (0.49 log units) above the measured one; the measured number lies below the stated range.
By their numbers in this assay, from the lowest: compounds 3 and 1 (each within the scatter of the next); then compound 2.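

In this assay, methyl in place of fluoro on an aromatic carbon para to a large group gives a 2.6-fold lower number from compound 2 to compound 3 (0.42 log units; beyond the scatter), so the number at this position depends on which of these two groups is present. The earlier exchange, hydrogen in place of fluoro on the other ring of the shared core, gave a 2.4-fold higher number from compound 1 to compound 2 (0.37 log units; beyond the scatter) and ran in the opposite direction; loss of fluoro therefore does not raise the number in every case here, although the two steps concern different rings and different incoming groups. No measurement in hand accounts for the difference between fluoro and methyl at this position.

On these data alone, whether the lower number seen with methyl extends to a longer chain such as ethyl, or to an oxygen-linked group such as methoxy, remains open, as does the outcome with an amine or a carboxylic acid at the same position. As far as these compounds go, it is also open whether methyl on the unsubstituted ring of compound 3 would move the number in the same direction.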